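The compounds below may be only part of what the source reports. "The series", "measured", "known", "first", "only" and "open" are said of these compounds alone.

Three compounds share one core and differ only in the bicyclic aromatic group attached to the urea nitrogen. Compound 1 `CC1CCN(c2nc(C(F)(F)F)ccc2CNC(=O)Nc2ccc3ccncc3c2)CC1` gives 8.4 nM in an assay on isolated protein for antagonist activity at transient receptor potential cation channel subfamily V member 1 (Homo sapiens), read by FLIPR (a lower number here means a stronger inhibitor, a higher number a weaker inhibitor), and compound 2 `CC1CCN(c2nc(C(F)(F)F)ccc2CNC(=O)Nc2ccc3cnncc3c2)CC1` gives 8.9 nM. Compound 3 `CC1CCN(c2nc(C(F)(F)F)ccc2CNC(=O)Nc2cccc3ncccc23)CC1` gives 0.7 nM, the lowest of the three numbers; its two neighbours sit well apart, as seen in a 12-fold lower number from compound 1 to compound 3 (1.08 log units; beyond the scatter) and a 13-fold lower number from compound 2 to compound 3 (1.10 log units; beyond the scatter). Compound 4 `CC1CCN(c2nc(C(F)(F)F)ccc2CNC(=O)Nc2cncc3ccccc23)CC1` carries the change (isoquinolin-4-yl in place of quinolin-5-yl on an amide-type nitrogen). The two steps into compound 3 show that rearranging the same kind of bicyclic group can move this assay by a large amount, while the step of a 1.1-fold higher number from compound 1 to compound 2 (0.03 log units; within the scatter) shows that swapping one ring nitrogen for another can also leave it unchanged. For the measured compounds named here, no measured step reports this exact rearrangement, so the direction is open, and a loss of part of the gain of compound 3 is the cautious expectation, expressed as a 4.3-fold higher number from compound 3 to compound 4 (0.63 log units; beyond the scatter). Compound 4 is therefore estimated at 3 nM, within a range from 0.7 nM to 15 nM.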

Compound 4, inhibition constant: 1.8 nM
Compound 4: the middle estimate sits 1.7-fold (0.22 log units) above what was measured, and the stated range covers the measured number.
By their numbers in this assay, from the lowest: compound 3; then compound 4; then compounds 1 and 2 (each within the scatter of the next).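

With the same atoms joined differently, isoquinolin-4-yl on the amide-type nitrogen gives up only part of what quinolin-5-yl achieved, as seen in a 2.6-fold higher number from compound 3 to compound 4 (0.41 log units; beyond the scatter) in this assay, so a low number here does not depend on quinolin-5-yl alone. The new group still holds a clear lead over isoquinolin-7-yl, shown by a 4.7-fold lower number from compound 1 to compound 4 (0.67 log units; beyond the scatter), and over the group of compound 2, shown by a 4.9-fold lower number from compound 2 to compound 4 (0.69 log units; beyond the scatter), which makes compound 4 a second compound well apart from compounds 1 and 2. No measurement here explains why these arrangements of the bicyclic group differ.

As far as these compounds go, what stays open is whether the ring nitrogen is needed at all, which naphthalen-1-yl, an all-carbon bicyclic group, would test. Also open, from the compounds shown here alone, is how an added amine or methoxy group on quinolin-5-yl or isoquinolin-4-yl would shift these numbers.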